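The compounds below may be only part of what the source reports. "The series", "measured", "known", "first", "only" and "open" are said of these compounds alone.

Compound 2 `CC(O)n1cnc2c(S)nc(F)nc21` is one of two compounds tested in a functional assay on HT-29 cells (Homo sapiens) for inhibition (a lower number here means a stronger inhibitor, a higher number a weaker inhibitor), and for it the assay gives only a limit: compound 2 reaches > 500000 nM. Compound 1 `CC(=O)OCCOn1cnc2c(S)nc(F)nc21` stands at the same point, since compound 1 likewise gives only a limit of > 500000 nM. For the measured compounds named here, both values therefore sit at the limit of > 500000 nM in this assay, at which 2 of the 2 values shown sit, so no step between measured compounds can be counted. Compound 3 `OCCOn1cnc2c(S)nc(F)nc21` carries the change (2-hydroxyethoxy in place of 1-hydroxyethyl on an aromatic nitrogen), which is 2-hydroxyethoxy in place of 1-hydroxyethyl on an aromatic nitrogen. With both neighbours at a limit, no step beyond the scatter is expected from compound 2 to compound 3, and the estimated result for compound 3 is again a limit, with an expected value of 500000 nM between 100000 nM and 1000000 nM, a step of a number no higher from compound 2 to compound 3 (the limit leaves the size open).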

Compound 3, half-maximal inhibitory concentration: > 500000 nM
Compound 3: no number, only a limit (the forecaster's own chance of this, stated with the estimate: 85%); the middle value lies on the limit itself.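

For the compounds shown here, compound 3 gives only a limit, as do compound 1 and compound 2, so no step from either of them to compound 3 can be read: the limit of > 500000 nM in this assay, at which 3 of the 3 values shown sit. The compounds shown leave open how strongly each inhibits and whether either change shifts that strength.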